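The source may hold more compounds than are shown below. What is called first, only, known or untested is meant among the compounds shown, and "the series" means these compounds.

Measured compounds:
- compound 1, `Nc1scc(CN2CCN(c3cccc(Cl)c3Cl)CC2)c1C(=O)c1ccc(Cl)cc1`, 2%
- compound 2, `Nc1scc(CN2CCN(c3ccccc3C(F)(F)F)CC2)c1C(=O)c1ccc(Cl)cc1`, 0%
- compound 3, `Nc1scc(CN2CCN(C3CCCCCC3)CC2)c1C(=O)c1ccc(Cl)cc1`, 0%

In an assay on CHO cells for displacement of a labelled ligand from adenosine receptor A1 (Homo sapiens), read by scintillation counting, with a stated time of 120 min, tested at 10 uM (on this read-out lower numbers stand for less inhibition and higher numbers for more inhibition at the one concentration tested (going by the name of the read-out)), compound 1 gives 2%, compound 2 gives 0% and compound 3 gives 0%. Compound 2 stands level with compound 3 at the digits shown, and the two together are the lowest of the three numbers. The first step is a number 2 percentage points lower from compound 1 to compound 2 (within the scatter), the other two are a number 2 percentage points lower from compound 1 to compound 3 (within the scatter) and no change at the digits printed from compound 2 to compound 3 (within the scatter), so every exchange of the group on the amine nitrogen in the ring so far leaves the read-out where it was.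

Compound 4, `Nc1scc(CN2CCN(c3cc(Cl)ccc3Cl)CC2)c1C(=O)c1ccc(Cl)cc1`, is not yet measured. It differs from compound 2 as follows: 2,5-dichlorophenyl in place of 2-(trifluoromethyl)phenyl on an amine nitrogen in a ring. For the measured compounds named here, the steps that bear on this are the exchanges at the same ring nitrogen, all within the scatter, and the nearest of them in kind is the one from compound 1, which carries a dichlorophenyl, to compound 2, a number 2 percentage points lower from compound 1 to compound 2 (within the scatter). No step beyond the scatter is therefore expected in this assay in either direction; the expected step is a number 2 percentage points higher from compound 2 to compound 4 (within the scatter). For compound 4 the estimate in this assay is 2%, with a range from -6% to 12%.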

Compound 4, a percentage reported as inhibition, at one concentration (the size of the read-out at that concentration, not a potency): 0%
Compound 4: middle estimate off by 2 percentage points, on the high side; the measured number falls inside the stated range.
By their numbers in this assay, from the lowest: compounds 2, 3, 4 and 1 (each within the scatter of the next).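

In this assay, for the compounds shown here, the exchange of 2,3-dichlorophenyl for 2,5-dichlorophenyl on the amine nitrogen in the ring gives a number 2 percentage points lower from compound 1 to compound 4 (within the scatter) and is the first comparison of two dichlorophenyl groups at this position, with no read-out separating them. The same group shows no change at the digits printed from compound 2 to compound 4 (within the scatter) against 2-(trifluoromethyl)phenyl and no change at the digits printed from compound 3 to compound 4 (within the scatter) against cycloheptyl, so all four groups on this nitrogen, aromatic or not, sit within the scatter of each other on the shared core. Nothing on hand accounts for this flat read-out.

Still open, from the compounds shown here alone, is whether any other group on this nitrogen, such as benzyl or a phenyl carrying a hydroxyl or an amine, would lift the read-out. Also open, going by these compounds, is whether the flat picture holds when the 4-chlorophenyl on the carbonyl gives way to a longer alkyl chain.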